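The source may report more compounds than this note shows. Statements on the series, on what has been measured and on what is new or still open speak of the compounds shown alone.

Measured in a functional assay on DU-145 cells (Homo sapiens) for antiproliferative activity, read by MTT assay, with a stated time of 72 h; a higher number here means a weaker inhibitor, a lower number a stronger inhibitor:
- Compound 1 `COc1cc2c(Nc3ccc(C#N)cc3)ncnc2cc1OCCCN(C)Cc1ccccc1`: > 100000 nM, a limit of the assay and not a number
- Compound 2 `COc1cc2c(Nc3ccc(C#N)cc3)ncnc2cc1OCCCN1CCC(c2ccccc2)CC1`: 6790 nM

For the measured compounds named here, compound 2 holds the only actual number so far, as the one other value is a limit. Compound 3 `CCN1CCN(CCCOc2cc3ncnc(Nc4ccc(C#N)cc4)c3cc2OC)CC1` keeps the shared core and the chain but carries 4-ethylpiperazin-1-yl in place of 4-phenylpiperidin-1-yl on a saturated chain carbon, three bonds along the chain from an oxygen on an aromatic ring. Going by the values given here, one measured step bears on this place, an at least 14-fold lower number from compound 1 to compound 2 (1.16 log units; beyond the scatter), and it is large. Among the compounds with values here, it shows that a swap on this saturated chain carbon can move the read-out far, but no measured step tests a piperazine ring. Compound 2 gives the better result of the pair, so a return towards weaker inhibition seems more likely than a further gain. The expected change in this assay is a 3.7-fold higher number from compound 2 to compound 3 (0.57 log units; beyond the scatter). For compound 3 the estimate is 25000 nM, with an expected range from 7000 nM to 90000 nM.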

Compound 3, half-maximal inhibitory concentration: 34400 nM
Compound 3: middle estimate off by 1.4-fold (0.14 log units), on the low side; the range from low to high includes it.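

In this assay, the first piperazine ring at this saturated chain carbon gives back part of what 4-phenylpiperidin-1-yl gained, with a 5.1-fold higher number from compound 2 to compound 3 (0.70 log units; beyond the scatter). It still does better than benzyl(methyl)amino, with an at least 2.9-fold lower number from compound 1 to compound 3 (0.46 log units; beyond the scatter), so among the three compounds both 4-phenylpiperidin-1-yl and 4-ethylpiperazin-1-yl give lower numbers than benzyl(methyl)amino. The value of compound 1 is a limit of the assay and not a number, so this last step gives only a minimum: the limit of > 100000 nM in this assay, at which 1 of the 3 values shown sits.

The change from compound 2 to compound 3 replaces the ring and its substituent at once, so the compounds shown cannot say which of the two accounts for the difference. They also leave open how a 4-phenylpiperazin-1-yl group, a morpholine ring or a longer chain would behave at this place.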